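Aryl substituent variation on the shared core: compound 4

The source may report more compounds than this note shows. Statements on the series, on what has been measured and on what is new or still open speak of the compounds shown alone.

Measured in an assay on isolated protein for binding affinity to histone acetyltransferase KAT2B (Homo sapiens), read by isothermal titration calorimetry; on this read-out higher numbers stand for weaker binding and lower numbers for tighter binding:
compound 1 `CN1C[C@H](Nc2nc3cc[nH]c3c(=O)n2C)C[C@H](c2cccc(Br)c2)C1` gives 128 nM
compound 2 `CN1C[C@H](Nc2nc3cc[nH]c3c(=O)n2C)C[C@H](c2ccc(O)cc2)C1` gives 120 nM
compound 3 `CC=CCn1c(N[C@@H]2C[C@H](c3ccccc3)CN(C)C2)nc2cc[nH]c2c1=O` gives 3040 nM

Compound 2 has the lowest number of the three, but its gap to compound 1 is within the scatter, so the two are not distinguished by these data; compound 3, which differs from compound 2 in more than one place, stands far higher. Compound 4 `COc1ccc([C@H]2C[C@@H](Nc3nc4cc[nH]c4c(=O)n3C)CN(C)C2)cc1` is not yet measured. It differs from compound 2 by methyl in place of hydrogen on an oxygen on an aromatic ring.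

Among the compounds with values here, the only single-point step in the set that touches the aryl group is a 1.1-fold lower number from compound 1 to compound 2 (0.03 log units; within the scatter), where the whole substituent pattern on the aromatic ring was exchanged and the number stayed within the scatter. Within the data shown here, no step in the set alters only the group on the oxygen, so the expectation for compound 4 rests on that one comparison and is correspondingly uncertain.

On this basis compound 4 is expected to stay close to compound 2, with an expected step in this assay of a 1.3-fold higher number from compound 2 to compound 4 (0.10 log units; within the scatter), that is, none beyond the scatter. The estimate for compound 4 is 150 nM, with a range from 60 nM to 400 nM.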

Compound 4, dissociation constant: 106 nM
Estimate against measurement, compound 4: 1.4-fold (0.15 log units) above, within the range that was stated.
By their numbers in this assay, from the lowest: compounds 4, 2 and 1 (each within the scatter of the next); then compound 3.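

In this assay, within the data shown here, replacing the hydrogen on the oxygen with methyl, hydroxy to methoxy, gives a 1.1-fold lower number from compound 2 to compound 4 (0.05 log units; within the scatter), the first step that alters only the group on that oxygen. At this position, then, the hydroxy and methoxy groups are not told apart by this read-out, and the change from 4-hydroxyphenyl to 4-methoxyphenyl leaves the number within the scatter. The exchange of 3-bromophenyl for 4-methoxyphenyl, a 1.2-fold lower number from compound 1 to compound 4 (0.08 log units; within the scatter), adds a second exchange of the whole aryl group that stays within the scatter, and no data here offer an explanation for why these aryl groups read alike.

Open, from the compounds shown here alone, is whether a longer chain on the oxygen, such as ethyl or benzyl, would keep the number within the scatter of compound 2, and whether an amine or a carboxylic acid in place of the hydroxy group would do the same. Also open, going by these compounds, is whether any group at this place can move the number beyond the scatter in either direction.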